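From ethyl to propyl on compound 2

A few compounds are considered here, and "the series" means these few. Any claim that something is new, unique, unknown or untested is made for them only; others in the source may bear on it.

Of the compounds shown here, two have been tested so far in a functional assay on the whole organism with Mus musculus as the target; a lower number here means that less compound is needed, a higher number that more compound is needed for the effect. Compound 1 `CCc1c(OC)nc2nc(-c3noc(C(F)(F)F)n3)cn2c1C` gives a limit of the assay and not a number: > 200 mg/kg. Among the measured compounds shown here, compound 2 `CCc1c(OC)nc2nc(-c3noc(C)n3)cn2c1C` gives 17 mg/kg, the only true number so far, so it cannot yet be ranked within a series. For the measured compounds named here, the single measured step is an at least 11-fold lower number from compound 1 to compound 2 (1.07 log units; beyond the scatter), with methyl in place of trifluoromethyl on an aromatic carbon.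

Compound 3 `CCCc1c(OC)nc2nc(-c3noc(C)n3)cn2c1C` differs from compound 2 at another place: methyl in place of hydrogen on a saturated chain carbon, two bonds along the chain from an aromatic carbon. This puts methyl in place of hydrogen on a saturated chain carbon, two bonds along the chain from an aromatic carbon, turning ethyl into propyl. Going by the values given here, no measured step touches this chain, so the data give no direction for the change. Still, an at least 11-fold lower number from compound 1 to compound 2 (1.07 log units; beyond the scatter) shows that one small change can move this assay a long way, so the expected range stays wide. With no stronger guide, the expected change is modest, a 1.2-fold higher number from compound 2 to compound 3 (0.07 log units; within the scatter). For compound 3 the estimated value is 20 mg/kg, with an expected range of 7 mg/kg to 60 mg/kg.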

Compound 3, dose for half-maximal effect: 16.5 mg/kg
Estimate against measurement, compound 3: 1.2-fold (0.08 log units) above; low and high end bracket the measured number.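

In this assay, adding a methyl to the chain of compound 2 turns ethyl into propyl and gives a 1.0-fold lower number from compound 2 to compound 3 (0.01 log units; within the scatter), so this one-carbon extension, on a saturated chain carbon two bonds along the chain from an aromatic carbon, leaves the two compounds indistinguishable. Among the compounds shown here, this is the first measured information about this chain, and it differs sharply from the only earlier step, an at least 11-fold lower number from compound 1 to compound 2 (1.07 log units; beyond the scatter), which came from methyl in place of trifluoromethyl at another place on the molecule, so a small change does not move this whole-animal reading everywhere. The flat step cannot be put down to the assay running out of range, since only compound 1 stands at a limit: the limit of > 200 mg/kg in this assay, at which 1 of the 3 values shown sits.

As far as these compounds go, a single step shows only that propyl matches ethyl here, and whether a longer chain such as butyl, or a branched group such as isopropyl, would also keep the number remains open. From the compounds shown here alone, it is equally open whether a polar end on this chain, such as an amine or a carboxylic acid, would leave the number where it stands.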